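Tert-butyl for methoxy on a dihydrofolate reductase triazine

The source may hold more compounds than are shown below. What is called first, only, known or untested is meant among the compounds shown, and "the series" means these compounds.

Measured so far:
compound 1 `COc1ccc(OCCCON2C(N)=NC(N)=NC23CCOCC3)cc1`: 11.1 nM
compound 2 `NC1=NC2(CCOCC2)N(OCCCOc2ccccc2Br)C(N)=N1`: "not determined" (no result reported)

Among the compounds with values here, compound 1 `COc1ccc(OCCCON2C(N)=NC(N)=NC23CCOCC3)cc1` is the only compound with a number here. In an assay on isolated protein for inhibition of Dihydrofolate reductase (Homo sapiens), read by spectrophotometry, using NADPH, with stated times of 5 s and 6 min (on this read-out higher numbers stand for weaker inhibition and lower numbers for stronger inhibition), compound 1 gives 11.1 nM. In this assay compound 2 `NC1=NC2(CCOCC2)N(OCCCOc2ccccc2Br)C(N)=N1` gives "not determined" (no result reported), so nothing can be compared with compound 1.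

Compound 3 `CC(C)(C)c1ccc(OCCCON2C(N)=NC(N)=NC23CCOCC3)cc1` differs from compound 1 by tert-butyl in place of methoxy on an aromatic carbon. Within the data shown here, no measured pair shows the effect of such a change, so the step is expected to be small, in either direction or none beyond the scatter; the estimated step is a 1.4-fold higher number from compound 1 to compound 3 (0.13 log units; within the scatter). Compound 3 is therefore expected at about 15 nM, between 4 nM and 50 nM.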

Compound 3, half-maximal inhibitory concentration: 3.72 nM
Compound 3: middle estimate off by 4.0-fold (0.61 log units), on the high side; measured number below the stated range.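

In this assay, tert-butyl in place of methoxy on this aromatic carbon gives a 3.0-fold lower number from compound 1 to compound 3 (0.47 log units; beyond the scatter), so this position accepts the larger group and inhibition grows stronger rather than being lost. In this one pair, the hydrogen-bond acceptor of the methoxy group is not needed to keep inhibition. No measurement here bears on why the number falls. The compounds shown leave open whether the gain follows the size of the group or the loss of its oxygen. They also leave open how a methyl group, an amine or a carboxylic acid would fare on the same carbon.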